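The source may report more compounds than this note shows. Statements on the series, on what has been measured and on what is new or still open speak of the compounds shown alone.

Compound 3, with the structure `CCCSc1nc(N/N=C(\C)c2ccccc2O)c2nnn(Cc3ccc(O)cc3)c2n1`, is one of three compounds whose growth inhibition was measured in a functional assay on ECa-109 cells (Homo sapiens) for antiproliferative activity, read by MTT assay, with a stated time of 72 h; a higher number here means a weaker inhibitor, a lower number a stronger inhibitor. In this assay compound 3 gives 15900 nM. Compound 1, with the structure `C#CCSc1nc(N/N=C/c2ccc(N(C)C)cc2)c2nnn(Cc3ccccc3)c2n1`, gives 31300 nM in this assay, and the two values sit within the usual scatter of each other, so no order between compound 3 and compound 1 can be read from them. Compound 2, with the structure `CCCSc1nc(N/N=C(\C)c2ccc(OC)cc2)c2nnn(Cc3ccccc3)c2n1`, reaches only the limit of this assay, > 64000 nM, and not a number; this is the case described by the limit of > 64000 nM in this assay, at which 1 of the 3 values shown sits.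

Compound 4, with the structure `CCCSc1nc(N/N=C(\C)c2ccccc2O)c2nnn(Cc3ccco3)c2n1`, is not yet measured. It differs from compound 3 in one place: furan-2-yl in place of 4-hydroxyphenyl on a saturated chain carbon bound to an aromatic nitrogen. Within the data shown here, no step between two measured compounds involves the same kind of change, so the effect of this exchange is unknown from the present data. The expectation for compound 4 in this assay is a value near that of compound 3, with the estimated step from compound 3 to compound 4 being a 1.4-fold higher number from compound 3 to compound 4 (0.14 log units; within the scatter), a change not clearly beyond the scatter in either direction. Compound 4 is therefore estimated at 22000 nM, within a range from 7000 nM to 64000 nM.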

Compound 4, half-maximal inhibitory concentration: 5760 nM
For compound 4 the middle estimate is 3.8-fold (0.58 log units) above the measured one; the whole stated range lies above it.
By their numbers in this assay, from the lowest: compound 4; then compounds 3 and 1 (each within the scatter of the next). At a limit, above all of these: compound 2.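

In this assay, the exchange of 4-hydroxybenzyl for (furan-2-yl)methyl brings a 2.8-fold lower number from compound 3 to compound 4 (0.44 log units; beyond the scatter), a modest step, but one that stands clear of the usual scatter. Compounds 1, 2 and 3 differ from one another in more than one place, so they could not show what a single change does; this step shows that the group on a saturated chain carbon bound to an aromatic nitrogen can alter the number on its own. It also shows that, with the rest of compound 3 kept, the six-membered ring and its hydrogen-bond donor are not needed for a number at this level. The five-membered furan-2-yl, with no donor, gives the lower one.

Nothing in the data shown explains why this exchange lowers the number. Going by these compounds, it also stays open whether the gain belongs to the furan-2-yl group in particular or would extend to other rings, and a thiophen-2-yl or a pyridin-3-yl group in the same place would help to tell these apart.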